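Removing the iodine from a diazabicyclic pyridine amide

The compounds below may be only part of what the source reports. "The series", "measured", "known", "first", "only" and "open" are said of these compounds alone.

Measured compounds:
- compound 1, `O=C(Nc1ccc(I)cc1)c1cncc(N2CC3CC(C2)N3)c1`, 0.366 nM
- compound 2, `O=C(c1cncc(N2CC3CC(C2)N3)c1)N1CCCc2ccccc21`, 0.196 nM
- compound 3, `COc1ccc(NC(=O)c2cncc(N3CC4CC(C3)N4)c2)cc1OC`, 0.828 nM

The three compounds share a core in which a pyridine carboxamide carries a bridged diamine, and they were tested in an assay on membranes from Cerebral cortex for displacement of a labelled ligand from Neuronal acetylcholine receptor; alpha4/beta2 (Rattus norvegicus); a higher number here means a weaker inhibitor, a lower number a stronger inhibitor. Compound 1 gives 0.366 nM, the second highest of the three numbers. Its nearest neighbour is compound 2, whose value of 0.196 nM lies within the scatter of that of compound 1, so no order between these two can be read. Compound 3, at 0.828 nM, stands beyond the scatter, with the higher number.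

Compound 4, `O=C(Nc1ccccc1)c1cncc(N2CC3CC(C2)N3)c1`, has not yet been measured. It differs from compound 1 by hydrogen in place of iodo on an aromatic carbon. Within the data shown here, no pair of measured compounds shows this change, so the expected step is uncertain. Since the remaining measured compounds give no guide, the expectation for compound 4 is a step of a 2.2-fold higher number from compound 1 to compound 4 (0.34 log units; beyond the scatter), a modestly higher number, at the edge of the scatter. Compound 4 is thus estimated at 0.8 nM, within a range from 0.3 nM to 2.5 nM.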

Compound 4, inhibition constant: 1.1 nM
Compound 4: middle estimate off by 1.4-fold (0.14 log units), on the low side; measured number inside the range.
By their numbers in this assay, from the lowest: compounds 2 and 1 (each within the scatter of the next); then compounds 3 and 4 (each within the scatter of the next).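

In this assay, among these compounds, the change from 4-iodophenyl to phenyl gives the first step that can be read at a single position: a 3.0-fold higher number from compound 1 to compound 4 (0.48 log units; beyond the scatter). The iodo on the aromatic carbon para to a large group therefore makes a real, though modest, difference, and the inhibitor is weaker with hydrogen in its place. Even so, compound 4 still gives 1.1 nM, so this single iodine atom is not needed for binding in the nanomolar range, and no measurement here accounts for the step.

The compounds shown leave open whether another group at this place, such as chloro, bromo, an amine or a carboxylic acid, would give a number nearer that of compound 1 or compound 4. They also leave open whether the same change would give a similar step on another amide, since this single pair is the only one that carries it.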